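Sulfonyl aryl exchange carried onto a second core

The compounds below may be only part of what the source reports. "The series", "measured", "known", "first", "only" and "open" are said of these compounds alone.

In an assay on isolated protein for displacement of a labelled ligand from metabotropic glutamate receptor 5 (Homo sapiens), with a stated time of 60 min, tested at 1 uM (on this read-out higher numbers stand for more inhibition at the one concentration tested (going by the name of the read-out) and lower numbers for less inhibition), compound 1 `CC1CCN(c2c(S(=O)(=O)c3cc(Cl)cc(Cl)c3)cnc3ccc(Cl)cc23)CC1` gives 88%, compound 2 `Cc1ccc(S(=O)(=O)c2cnc3ccc(Cl)cc3c2N2CCC(C)CC2)cc1F` gives 68%, and compound 3 `Cc1ccc(S(=O)(=O)c2cnc3c(F)cccc3c2N2CCC(C)CC2)cc1F` gives 93%. The change 3,5-dichlorophenyl in place of 3-fluoro-4-methylphenyl on a sulfonyl sulfur produces a number 20 percentage points higher from compound 2 to compound 1 (beyond the scatter). The difference between the core of compound 2 and the core of compound 3 is not broken down here. Compound 4 `CC1CCN(c2c(S(=O)(=O)c3cc(Cl)cc(Cl)c3)cnc3c(F)cccc23)CC1` has not yet been measured in this assay; it carries the same change as that from compound 2 to compound 1, namely (3,5-dichlorophenyl in place of 3-fluoro-4-methylphenyl on a sulfonyl sulfur), placed on the core of compound 3. A smaller step than before is expected, a number 2 percentage points higher from compound 3 to compound 4 (within the scatter), because compound 3 already stands at 93% and the read-out leaves little room above it. For compound 4 a value of 95% is estimated, with a likely range from 87% to 100%.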

Compound 4, a percentage reported as inhibition, at one concentration (the size of the read-out at that concentration, not a potency): 82%
For compound 4 the middle estimate is 13 percentage points above the measured one; the measured number lies below the stated range.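

On the core of compound 3, 3,5-dichlorophenyl in place of 3-fluoro-4-methylphenyl on a sulfonyl sulfur gives a number 11 percentage points lower from compound 3 to compound 4 (beyond the scatter). The effect of this exchange does not carry over from one core to the other, in size or in direction: the same change on two cores in this assay, a number 20 percentage points higher (beyond the scatter) from compound 2 to compound 1 and a number 11 percentage points lower (beyond the scatter) from compound 3 to compound 4, 31 percentage points apart, beyond the scatter of two such steps

In this pair of cores, the outcome of the exchange therefore depends on the core, but the result does not show why, and two pairs give no rule for any other core.

No pair shown separates which part of the difference between the two cores matters. Also open, as far as these compounds go, is whether a phenyl carrying a methoxy group or a nitrile on the sulfonyl sulfur would depend on the core in the same way.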